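A few compounds are considered here, and "the series" means these few. Any claim that something is new, unique, unknown or untested is made for them only; others in the source may bear on it.

Compound 1 `COc1cc2c(cc1O)CCC(C)(CC(=O)O)O2` gives 61% in an ADME assay on SH-SY5Y cells (Homo sapiens) for cytotoxicity, read by MTT assay, with a stated time of 24 h, tested at 50 uM (a higher number here means a weaker effect of the compound at the concentration tested, a lower number a stronger effect), the lowest of the three numbers recorded there. Compound 2 `COc1cc2c(cc1O)CCC(C)(CC(=O)N[C@@H](C)C(=O)O)O2` gives 100% in this assay, and compound 3 `COc1cc2c(cc1O)CCC(C)(CC(=O)N[C@@H](CCC(N)=O)C(=O)O)O2` gives 83.2%. The step of a number 39 percentage points higher from compound 1 to compound 2 (beyond the scatter) is large and lies beyond the scatter; the step of a number 16.8 percentage points lower from compound 2 to compound 3 (beyond the scatter) is modest, also beyond the scatter. Compound 4 `COc1cc2c(cc1O)CCC(C)(CC(N)C(=O)O)O2` has not yet been measured in this assay. It differs from compound 1 as follows: amino(carboxy)methyl in place of carboxy on a saturated chain carbon bound to a saturated ring carbon. Among the measured compounds shown here, no measured step makes exactly this change. The closest comparison is the step of a number 39 percentage points higher from compound 1 to compound 2 (beyond the scatter), in which the same carboxy group of compound 1 was altered at its carbonyl carbon. In compound 4 a carboxy group remains present within the amino(carboxy)methyl group that enters, so a rise smaller than that large step is expected. The expected step is a number 14 percentage points higher from compound 1 to compound 4 (beyond the scatter). Compound 4 is therefore estimated to give 75% in this assay, within a range from 55% to 95%.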

Compound 4, a percentage reported as activity, at one concentration (the size of the read-out at that concentration, not a potency): 85.7%
For compound 4 the middle estimate is 10.7 percentage points below the measured one; low and high end bracket the measured number.
By their numbers in this assay, from the lowest: compound 1; then compounds 3 and 4 (each within the scatter of the next); then compound 2.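

The change at this position, on a saturated chain carbon bound to a saturated ring carbon, gives a number 24.7 percentage points higher from compound 1 to compound 4 (beyond the scatter) in this assay. Among the compounds shown here, until now, the only rise from compound 1 had come with an amide-type nitrogen on the carbonyl carbon, as in compound 2 and, with its carbamoylmethyl group, compound 3; compound 4 shows that a higher number can also be reached with amino(carboxy)methyl in place of carboxy, with no such amide link. No measurement shown here accounts for this rise in the number.

The compounds leave open whether the amine or the carboxylic acid within the entering group goes with the rise, which aminomethyl, holding the amine alone, could help to settle. They also leave open what a longer chain carrying the same amine and carboxylic acid would give in this assay.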